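The compounds below may be only part of what the source reports. "The series", "measured", "known", "first", "only" and "open" are said of these compounds alone.

Compound 1 `Cn1c(=O)c(=O)n(C2CCCC2)c2nc(N/N=C/c3ccccc3)ncc21` gives > 100000 nM in a functional assay on HCT-116 cells (Homo sapiens) for antiproliferative activity, read by MTT assay (on this read-out lower numbers stand for stronger inhibition and higher numbers for weaker inhibition), which is a limit of the assay rather than a number.
Compound 2 `Cn1c(=O)c(=O)n(C2CCCC2)c2nc(N/N=C/c3ccc(O)cc3)ncc21` gives 72500 nM in this assay.
Compound 3 `Cn1c(=O)c(=O)n(C2CCCC2)c2nc(N/N=C/c3ccc(O)c(Br)c3)ncc21` gives 17700 nM in this assay.

Among the three, compound 1 stands at the limit of > 100000 nM in this assay, at which 1 of the 3 values shown sits, so its exact number is unknown. Compound 4 `Cn1c(=O)c(=O)n(C2CCCC2)c2nc(N/N=C/c3cc([N+](=O)[O-])ccc3Cl)ncc21` carries 2-chloro-5-nitrophenyl in place of phenyl on a carbon with a double bond to nitrogen. Among the measured compounds shown here, no measured step makes this exact change; the nearest are an at least 1.3-fold lower number from compound 1 to compound 2 (0.13 log units; that floor lies within the scatter), an at least 5.6-fold lower number from compound 1 to compound 3 (0.75 log units; beyond the scatter) and a 4.1-fold lower number from compound 2 to compound 3 (0.61 log units; beyond the scatter), in which decorating the phenyl lowered the number, the bromo alone giving a modest step. The change to compound 4 also adds a chlorine, as the bromo did in a 4.1-fold lower number from compound 2 to compound 3 (0.61 log units; beyond the scatter), so a downward step of similar size is expected. Compound 4 is therefore estimated at about 40000 nM (range 10000 nM to 150000 nM), meaning an at least 2.5-fold lower number from compound 1 to compound 4 (0.39 log units; beyond the scatter).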

Compound 4, half-maximal inhibitory concentration: 5610 nM
The estimate for compound 4 lay 7.1-fold (0.85 log units) above the measured number; measured number below the stated range.
By their numbers in this assay, from the lowest: compound 4; then compound 3; then compound 2. At a limit, above all of these: compound 1.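

At this position, a hydroxy group is not needed for a low number in this assay: 2-chloro-5-nitrophenyl, with no hydrogen-bond donors, gives a 13-fold lower number from compound 2 to compound 4 (1.11 log units; beyond the scatter) and a 3.2-fold lower number from compound 3 to compound 4 (0.50 log units; beyond the scatter). Against plain phenyl it gives an at least 17-fold lower number from compound 1 to compound 4 (1.25 log units; beyond the scatter), which is only a floor, since compound 1 stands at a limit: the limit of > 100000 nM in this assay, at which 1 of the 4 values shown sits.

The compounds shown do not separate the chloro from the nitro, so the share of each in these steps remains unknown. On these data alone, whether an amine or a carboxylic acid on this phenyl would lower the number further also remains open.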